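Methoxy for dimethylcarbamoyl at a solubility limit

This account rests on a few compounds, and the source may have more. Where it says the series, first, only, none or still open, it means among the compounds named here.

Measured in a physicochemical assay for solubility; a lower number here means a less soluble compound, a higher number a more soluble compound:
- Compound 1 `O=C(Nc1c(Cl)cc(F)cc1Cl)c1cc(Cl)ccc1O`: > 49 ug/mL
- Compound 2 `CN(C)C(=O)c1cccc(NC(=O)c2cc(Cl)ccc2O)c1`: > 47 ug/mL

Compound 2 stands at > 47 ug/mL, which is a limit and not a number. The reading for compound 1 is also only a limit. Compound 3 `COc1cccc(NC(=O)c2cc(Cl)ccc2O)c1` differs from compound 2 by methoxy in place of dimethylcarbamoyl on an aromatic carbon, meta to a large group (methoxy in place of dimethylcarbamoyl on an aromatic carbon). For the measured compounds named here, no measured pair shows this change, and the two limits give no size for it. In this assay, the expected step of an at least 1.1-fold lower number from compound 2 to compound 3 (0.07 log units; that floor lies within the scatter) is none beyond the scatter. Compound 3 is estimated at 40 ug/mL, with an expected range of 15 ug/mL to 50 ug/mL.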

Compound 3, solubility: 2.3 ug/mL
Compound 3: the middle estimate sits 17-fold (1.24 log units) above what was measured, and the stated range ends above it.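

In this assay, the position meta to a large group proves sensitive to what it carries: methoxy in place of dimethylcarbamoyl on an aromatic carbon gives an at least 20-fold lower number from compound 2 to compound 3 (1.31 log units; beyond the scatter). For the compounds shown here, compound 3, at 2.3 ug/mL, also supplies the first reading here that is a number and not a limit. Compound 2 gives only a limit, so the full size of the step cannot be read: the limit of > 47 ug/mL in this assay, at which 1 of the 3 values shown sits.

From the compounds shown here alone, this rests on a single pair, so it remains open whether the drop belongs to losing dimethylcarbamoyl or to gaining methoxy. Going by these compounds, how an amine or a carboxylic acid would read at this position also remains open.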